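A few compounds are considered here, and "the series" means these few. Any claim that something is new, unique, unknown or untested is made for them only; others in the source may bear on it.

Compound 1 (`Nc1c([S+]([O-])CCCF)sc2nc(-c3cccs3)cc(-c3ccccc3)c12`): in an assay for inhibition of 15-hydroxyprostaglandin dehydrogenase [NAD(+)] (Homo sapiens), read by fluorescence, with a stated time of 15 min, in the presence of a further agent that is not named here (on this read-out lower numbers stand for stronger inhibition and higher numbers for weaker inhibition), compound 1 gives 6.1 nM.
Compound 2 (`CCCC[S+]([O-])c1sc2nc(-c3nccs3)cc(-c3cnc(C)[nH]3)c2c1N`): in this assay compound 2 gives 2.3 nM.

Of these two numbers, compound 1 has the higher one, and compound 2 sits lower by a gap that is beyond the usual scatter of this kind of measurement. Compound 3 (`CCCCSc1sc2nc(-c3cccs3)cc(-c3ccccc3)c2c1N`) has not yet been measured. It differs from compound 1 in one place: a group of 5 heavy atoms (4 carbon, 1 sulfur; no ring) in place of a group of 6 heavy atoms (3 carbon, 1 oxygen, 1 fluorine, 1 sulfur; no ring), on an aromatic carbon. Among the compounds with values here, no measured pair shows this change by itself; compound 2 also carries a butyl chain on its sulfur, but its sulfur still bears an oxygen and its two rings differ too, so its value cannot stand for this step. The expected step is a 1.3-fold higher number from compound 1 to compound 3 (0.12 log units; within the scatter), a modest one that need not be beyond the scatter. The estimate for compound 3 is 8 nM, with a range from 2 nM to 30 nM.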

Compound 3, half-maximal inhibitory concentration: > 80 nM
Compound 3 gave a limit, no number; the forecaster's own chance of this, stated with the estimate: 3%; middle value at least 10-fold (1.00 log units) away from the limit.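

In this assay, the group on this aromatic carbon, next to the ring sulfur, proves far more sensitive than the similar sizes of the two groups might suggest: exchanging it for butylsulfanyl gives an at least 13-fold higher number from compound 1 to compound 3 (1.11 log units; beyond the scatter). The result for compound 3 is a limit of the assay, not a number: the limit of > 80 nM in this assay, at which 1 of the 3 values shown sits. The exchange removes the oxygen on the sulfur and the fluorine on the chain together, and inhibition clearly weakens with it.

The compounds shown cannot separate the oxygen, the fluorine and the change of chain, so it remains unclear which of them accounts for the loss. On these data alone, how a sulfone, with two oxygens on the sulfur, or an amine at this place would behave on the core of compound 1 also stays open.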